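The source may hold more compounds than are shown below. What is called first, only, known or untested is meant among the compounds shown, and "the series" means these compounds.

Three compounds sharing one core have been examined in a functional assay on SF-268 cells (Homo sapiens) for inhibition, read by sulforhodamine B assay, with a stated time of 48 h; a lower number here means a stronger inhibitor of growth, a higher number a weaker inhibitor of growth. Compound 1, `COc1cc(-c2nn(-c3cccc(NC(=O)c4cccc(C(F)(F)F)c4)c3)cc2-c2ccncc2)ccc1Cl`, carries an amide whose carbonyl is joined directly to a 3-(trifluoromethyl)phenyl group. In this assay compound 1 gives > 50000 nM, which is a limit of the assay rather than a number (the limit of > 50000 nM in this assay, at which 1 of the 3 values shown sits). Compound 2, `COc1cc(-c2nn(-c3cccc(NC(=O)Nc4ccc(Cl)c(Cl)c4)c3)cc2-c2ccncc2)ccc1Cl`, is a urea instead, ending in a 3,4-dichlorophenyl group, and in this assay compound 2 gives 20300 nM. Compound 3, `COc1cc(-c2nn(-c3cccc(NC(=O)Nc4cccc(C(F)(F)F)c4)c3)cc2-c2ccncc2)ccc1Cl`, is the urea ending in a 3-(trifluoromethyl)phenyl group, and in this assay compound 3 gives 5430 nM, the lowest of the two numbers shown; the nearest other number stands a 3.7-fold lower number from compound 2 to compound 3 (0.57 log units; beyond the scatter) away. The two remaining steps were an at least 2.4-fold lower number from compound 1 to compound 2 (0.39 log units; beyond the scatter) and an at least 9.2-fold lower number from compound 1 to compound 3 (0.96 log units; beyond the scatter). Compound 4, `COc1cc(-c2nn(-c3cccc(NC(=O)Nc4ccc(Cl)c(C(F)(F)F)c4)c3)cc2-c2ccncc2)ccc1Cl`, differs from compound 3 by a single change: chloro in place of hydrogen on an aromatic carbon. Within the data shown here, no measured step tests this addition on its own; the closest comparison is a 3.7-fold lower number from compound 2 to compound 3 (0.57 log units; beyond the scatter), in which a 3,4-dichlorophenyl group gave way to a 3-(trifluoromethyl)phenyl group, a modest move. Compound 4 keeps the trifluoromethyl group and adds one chloro, so the step expected here is small, a 1.1-fold lower number from compound 3 to compound 4 (0.04 log units; within the scatter). Compound 4 is therefore estimated to give about 5000 nM in this assay, with a likely range from 2000 nM to 15000 nM.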

Compound 4, concentration for total growth inhibition: 9140 nM
Compound 4: the middle estimate sits 1.8-fold (0.26 log units) below what was measured; the measured number falls inside the stated range.
By their numbers in this assay, from the lowest: compounds 3 and 4 (each within the scatter of the next); then compound 2. At a limit, above all of these: compound 1.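

Among these compounds, on the aromatic carbon ortho to the trifluoromethyl group and para to a large group, chloro in place of hydrogen gives a 1.7-fold higher number from compound 3 to compound 4 (0.23 log units; within the scatter), so in this assay this position carries a chloro with no step that can be read. The earlier comparison of a 3,4-dichlorophenyl group with a 3-(trifluoromethyl)phenyl group altered two places at once; with this chloro held constant, trifluoromethyl in place of chloro gives a 2.2-fold lower number from compound 2 to compound 4 (0.35 log units; beyond the scatter), so the step beyond the scatter belongs to that swap and not to the chloro added here. The urea ending in the 4-chloro-3-(trifluoromethyl)phenyl group also stands clear of the amide, an at least 5.4-fold lower number from compound 1 to compound 4 (0.73 log units; beyond the scatter), though the size of this step stays open-ended, as compound 1 sits at a limit of the assay: the limit of > 50000 nM in this assay, at which 1 of the 4 values shown sits.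

As far as these compounds go, whether a different group at this position, such as a methoxy, a methyl or an amine, would move the number beyond the scatter remains open. Also open, from the compounds shown here alone, is whether a chloro here would behave the same way on the amide of compound 1, whose reading gives no number to compare against.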